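The compounds below may be only part of what the source reports. "The series", "measured", "known", "first", "only" and "open" are said of these compounds alone.

Working notes on the series in a functional assay on HeLa cells (Homo sapiens) for antiproliferative activity, read by sulforhodamine B assay, with a stated time of 72 h; a lower number here means a stronger inhibitor, a higher number a weaker inhibitor. Compound 1 (`COc1ccccc1NC(=S)N/N=C/c1ccc2ccccc2n1`) is reported only as a limit, > 100000 nM. Compound 3 (`NC(=S)N/N=C/c1ccc2cccnc2n1`) is also reported only as a limit, > 100000 nM. Compound 2 (`CN(C)C(=S)N/N=C/c1cc2cccnc2s1`) gives a number, 48400 nM. Compound 1 therefore stands with compound 3 at the limit of > 100000 nM in this assay, at which 2 of the 3 values shown sit.

Compound 4 (`Cc1ccc(NC(=S)N/N=C/c2ccc3ccccc3n2)cc1`) has not yet been measured and is read here against compound 1. The structural change is 4-methylphenyl in place of 2-methoxyphenyl on an amide-type nitrogen, with the rest of compound 1 kept. Going by the values given here, no measured pair isolates a change at this place, so any expectation is loose. A modest gain in this assay is expected, and a second limit remains a real possibility. So far only compound 2 gives a number, 48400 nM. The expected step is an at least 2.5-fold lower number from compound 1 to compound 4 (0.39 log units; beyond the scatter), toward stronger inhibition. For compound 4 the estimated value is 40000 nM, with an expected range from 8000 nM to 100000 nM.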

Compound 4, half-maximal inhibitory concentration: 86000 nM
Beside the measured number, compound 4's estimate is 2.2-fold (0.33 log units) below it; the measured number falls inside the stated range.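

In this assay, the change of 2-methoxyphenyl to 4-methylphenyl on the amide-type nitrogen gives the first step read at this place: an at least 1.1-fold lower number from compound 1 to compound 4 (0.06 log units; that floor lies within the scatter). Going by these compounds alone, compound 4 gives a number, 86000 nM, which shows that a measurable value can be reached with the core of compound 1 kept and only this group changed. The step has only a floor because compound 1 is reported as a limit, so its true size cannot be read: the limit of > 100000 nM in this assay, at which 2 of the 4 values shown sit.

The single swap removes the methoxy group and adds the methyl group together, so the compounds shown do not separate the two, and a plain phenyl would be the missing reference. On these data alone, how this place responds to a phenyl carrying an amine or a carboxylic acid, or to a longer alkyl chain in place of the aryl group, also remains open.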